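Methyl for Chloro on a Second Core

The source may report more compounds than this note shows. Statements on the series, on what has been measured and on what is new or still open speak of the compounds shown alone.

Measured compounds:
compound 1 `COc1ccc(Cn2c(NCCNC(=N)N)nc(=O)n(Cc3ccc(C)cc3)c2=O)cc1` 0.0044 nM
compound 2 `COc1ccc(Cn2c(NCCNC(=N)N)nc(=O)n(Cc3ccc(Cl)cc3)c2=O)cc1` 0.004 nM
compound 3 `COc1ccc(Cn2c(=O)nc(NCCNC(=N)N)n(Cc3ccc(Cl)cc3)c2=O)cc1` 0.0044 nM

Of the compounds shown here, three have been tested in a functional assay on the whole organism (strain C57Bl/6) for inhibition, with Mus musculus as the target, with a stated time of 180 min, at 48 degrees C; on this read-out lower numbers stand for an effect already at smaller amounts and higher numbers for an effect only at larger amounts of compound. In this assay compound 2 gives 0.004 nM, and compound 1, which carries the change (methyl in place of chloro on an aromatic carbon), gives 0.0044 nM. The step of a 1.1-fold higher number from compound 2 to compound 1 (0.04 log units; within the scatter) lies within the scatter, so the two values are read as the same.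

Compound 3, with 0.0044 nM in this assay, is built on a different core: it has the same atoms as compound 2 joined differently, and the difference between the two cores is not broken down here. Its value sits level with compound 1 and within the scatter of compound 2.

Compound 4 `COc1ccc(Cn2c(=O)nc(NCCNC(=N)N)n(Cc3ccc(C)cc3)c2=O)cc1` has not yet been measured. It differs from compound 3 by methyl in place of chloro on an aromatic carbon, which is the same change already seen from compound 2 to compound 1, at the same place. Because a 1.1-fold higher number from compound 2 to compound 1 (0.04 log units; within the scatter) made no difference beyond the scatter, compound 4 is expected to stay close to compound 3, with an expected step of a 1.1-fold higher number from compound 3 to compound 4 (0.03 log units; within the scatter) in this assay. The expectation rests on one pair only, so it is held loosely. Compound 4 is estimated to give 0.0047 nM in this assay, with a range from 0.0024 nM to 0.0095 nM expected.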

Compound 4, half-maximal effective concentration: 0.0045 nM
Estimate against measurement, compound 4: 1.0-fold (0.02 log units) above, within the range that was stated.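

On the second core, methyl in place of chloro on the aromatic carbon gives a 1.0-fold higher number from compound 3 to compound 4 (0.01 log units; within the scatter) in this assay, so the change leaves the read-out where it stood, as it did on the first core. Set side by side, the two steps cannot be told apart, and in this small series the change carries from one core to the other without a visible difference: the same change on two cores in this assay, a 1.1-fold higher number (0.04 log units; within the scatter) from compound 2 to compound 1 and a 1.0-fold higher number (0.01 log units; within the scatter) from compound 3 to compound 4, 1.1-fold (0.03 log units) apart, within the scatter of two such steps. Going by these compounds alone, this rests on a single pair per core and on one assay, and it shows only that this one change is silent on these two cores; it does not show why, does not show that other changes would carry across in the same way, and does not extend to any further core.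

With only chloro and methyl shown at this place, it stays open whether a group such as trifluoromethyl, a nitrile or a carboxylic acid on that aromatic carbon would shift the number on either core. From the compounds shown here alone, it also stays open whether a longer chain to the guanidine, or a plain amine in its place, would keep the two cores level with each other.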